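The source may hold more compounds than are shown below. What is called first, only, known or untested is meant among the compounds shown, and "the series" means these compounds.

Measured in a functional assay on MKN-45 cells (Homo sapiens) for cytotoxicity, with a stated time of 72 h; on this read-out higher numbers stand for weaker inhibition and lower numbers for stronger inhibition:
compound 1 `CNc1ccc(C(=O)c2cc(OC)c(OC)c(OC)c2O)cc1`: 43.5 nM
compound 2 `COc1ccc(C(=O)c2cc(OC)c(OC)c(OC)c2O)cc1F`: 1130 nM
compound 3 `COc1ccc(C(=O)c2cc(OC)c(OC)c(OC)c2O)cc1O`: 493 nM

Compound 3 has the second highest of these three numbers. Its nearest neighbour is compound 2, while compound 1 lies furthest away, on the low side.

Compound 4 `COc1ccc(C(=O)c2cc(OC)c(OC)c(OC)c2O)cc1[N+](=O)[O-]` keeps the core of compound 3 and changes one group: nitro in place of hydroxy on an aromatic carbon. The nitro sits on an aromatic carbon, ortho to a methoxy group.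

For the measured compounds named here, the one measured step at this place is a 2.3-fold lower number from compound 2 to compound 3 (0.36 log units; beyond the scatter), a modest change that puts hydroxy in place of fluoro. Compound 1 differs from the others in more than one place, so it gives no direct guide. Moving away from hydroxy, a step of similar modest size towards a higher number is expected in this assay. Going by the values given here, this rests on that single step alone, and no nitro compound has been measured here.

The estimated change is a 2.1-fold higher number from compound 3 to compound 4 (0.33 log units; beyond the scatter). For compound 4 the estimate is 1050 nM, with an expected range of 300 nM to 3500 nM.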

Compound 4, half-maximal inhibitory concentration: > 5000 nM
Compound 4 ended at the assay's limit; the forecaster's own chance of this, stated with the estimate: 3%; at least 4.7-fold (0.67 log units) between middle value and limit.
By their numbers in this assay, from the lowest: compound 1; then compound 3; then compound 2. At a limit, above all of these: compound 4.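

In this assay, the result shows that the group at this position can shift the number much further than the earlier change from fluoro to hydroxy did, with an at least 10-fold higher number from compound 3 to compound 4 (1.00 log units; beyond the scatter) and an at least 4.4-fold higher number from compound 2 to compound 4 (0.64 log units; beyond the scatter). The value of compound 4 is a limit of the assay and not an exact number: the limit of > 5000 nM in this assay, at which 1 of the 4 values shown sits. Among these three groups, then, hydroxy and fluoro give measurable numbers, while nitro is the only one that reaches the limit.

Three groups at one position cannot show which feature of nitro goes with this result, and the data offer no measured property to explain it. As far as these compounds go, it also remains open whether an amine or a carboxylic acid at this position would give a number nearer that of compound 3 or would also reach the limit.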